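Indole hydrazone series: removing the bromo substituent

The source may report more compounds than this note shows. Statements on the series, on what has been measured and on what is new or still open speak of the compounds shown alone.

Of the compounds shown here, three have been measured in a functional assay on PC-3 cells (Homo sapiens) for cytotoxicity; a lower number here means a stronger inhibitor, a higher number a weaker inhibitor. Compound 1 `COc1ccc(Cn2cc(/C=N\NC(=O)c3c[nH]c4ccccc34)c3ccccc32)cc1` gives 14600 nM, compound 2 `COc1ccc(Cn2cc(/C=N\NC(=O)c3c[nH]c4ccc(Br)cc34)c3cc(OC)ccc32)cc1` gives 28000 nM, and compound 3 `COc1ccc2c(c1)c(/C=N\NC(=O)c1c[nH]c3ccc(Br)cc13)cn2Cc1ccc(Cl)cc1` gives 15900 nM. Within this set compound 3 stands second highest, nearest to compound 1 and furthest from compound 2, with both gaps within the scatter. For the measured compounds named here, the only single-point step measured so far, a 1.8-fold lower number from compound 2 to compound 3 (0.25 log units; within the scatter), is likewise within the scatter.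

Compound 4 `COc1ccc2c(c1)c(/C=N\NC(=O)c1c[nH]c3ccccc13)cn2Cc1ccc(Cl)cc1` differs from compound 3 by hydrogen in place of bromo on an aromatic carbon. Going by the values given here, no measured step isolates this change: compound 1 and compound 2 differ in two places, so their values are only noted as they stand and show no clear gap either. Among the compounds with values here, with the one measured step within the scatter and nothing bearing directly on the bromo position, no movement beyond the scatter is expected in this assay, and the step of a 1.1-fold lower number from compound 3 to compound 4 (0.03 log units; within the scatter) is estimated accordingly. Compound 4 is therefore expected to give about 15000 nM, in a range from 6000 nM to 40000 nM.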

Compound 4, half-maximal inhibitory concentration: 30300 nM
The estimate for compound 4 lay 2.0-fold (0.31 log units) below the measured number; the measured number falls inside the stated range.
By their numbers in this assay, from the lowest: compounds 1, 3, 2 and 4 (each within the scatter of the next, the first and the last beyond it).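

In this assay, for the compounds shown here, the change from 5-bromo-1H-indol-3-yl to 1H-indol-3-yl gives a 1.9-fold higher number from compound 3 to compound 4 (0.28 log units; within the scatter), the first reading that isolates this position. On the core of compound 3, the bromo on this aromatic carbon therefore makes no difference that can be told from the scatter, so the assay gives no sign that this atom is needed for the cytotoxic effect seen at these concentrations. No measurement on hand accounts for the step or links it to any property of the bromo group.

Going by these compounds, whether the same reading holds on the core of compound 1, which carries a different group on the ring nitrogen side and lacks the methoxy of compound 3, stays open. Also open, on these data alone, is what an amine, a carboxylic acid or a longer chain on this same aromatic carbon would give in this assay.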